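The source may hold more compounds than are shown below. What is called first, only, known or untested is meant among the compounds shown, and "the series" means these compounds.

In a functional assay on MCF7 cells (Homo sapiens) for antiproliferative activity, read by MTT assay, with a stated time of 48 h (a lower number here means a stronger inhibitor, a higher number a weaker inhibitor), compound 1 (`C=C1[C@H](OCC(C)C)[C@@H](OC(C)=O)[C@@H](OC(C)=O)C(C)(C)[C@@H]2O[C@H]2[C@H](C)[C@H](OC(=O)c2ccccc2)[C@@]2(O)C[C@@](C)(OC(C)=O)[C@H](OC(C)=O)[C@@H]2[C@H]1OCC(C)C`) reads > 100000 nM as a limit of the assay. Compound 2 (`C=C1[C@H](OC(C)=O)[C@@H](OC(C)=O)[C@@H](OC(C)=O)C(C)(C)/C=C/[C@H](C)[C@H]2O[C@]3(C)C[C@@]2(OC(=O)c2ccccc2)[C@H]([C@H]3OC(C)=O)[C@H]1OCC(C)C`) reads > 100000 nM as a limit too. Compound 3 (`C=C1[C@H](OC(C)=O)[C@@H](OC(=O)c2cccc(C)c2)[C@@H](OC(C)=O)C(C)(C)/C=C/[C@H](C)[C@H]2O[C@]3(C)C[C@@]2(OC(=O)c2ccccc2)[C@H]([C@H]3OC(C)=O)[C@H]1OCC(C)C`) reads > 100000 nM and this is again a limit, so it has no number of its own. All the measured compounds rest on one reading (the limit of > 100000 nM in this assay, at which 3 of the 3 values shown sit).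

Compound 4 (`C=C1[C@H](OC(C)=O)[C@@H](OC(=O)C(C)(C)C)[C@@H](OC(C)=O)C(C)(C)/C=C/[C@H](C)[C@H]2O[C@]3(C)C[C@@]2(OC(=O)c2ccccc2)[C@H]([C@H]3OC(C)=O)[C@H]1OCC(C)C`) differs from compound 3 in one place, with tert-butyl in place of 3-methylphenyl on a carbonyl carbon. Within the data shown here, the one measured step at a carbonyl carbon is a step that the two limits leave unreadable from compound 2 to compound 3 and it offers no size to carry over. Among the measured compounds shown here, no step of definite size can therefore be expected in this assay, and no direction beyond the scatter is expected either. The expected change is a number no higher from compound 3 to compound 4 (the limit leaves the size open) and it is only nominal. For compound 4 the estimate is 100000 nM with an expected range from 40000 nM to 200000 nM and the most likely outcome is another limit rather than a number.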

Compound 4, half-maximal inhibitory concentration: > 100000 nM
Compound 4: no number, only a limit (the forecaster's own chance of this, stated with the estimate: 85%); the middle value lies on the limit itself.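

Compound 4 gives another limit, so neither the step to it from compound 2 nor the step from compound 3 can be read, because all the compounds rest on one reading: the limit of > 100000 nM in this assay, at which 4 of the 4 values shown sit.

The compounds shown leave open whether any group on this carbonyl carbon changes the activity, and by how much.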